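Anomeric configuration in a biphenyl-ether glucoside pair

The source may hold more compounds than are shown below. What is called first, only, known or untested is meant among the compounds shown, and "the series" means these compounds.

Measured so far:
compound 1 `CO[C@H]1O[C@H](COc2ccc(-c3ccccc3)cc2)[C@@H](O)[C@H](O)[C@H]1Oc1cccc(C(C)C)c1` — 30000 nM
compound 2 `CO[C@H]1O[C@H](COc2ccc(-c3ccccc3)cc2)[C@@H](O)[C@H](O)[C@H]1Oc1ccccc1C(C)C` — 34000 nM

Going by the values given here, in a functional assay on MDA-MB-231 cells (Homo sapiens) for cytotoxicity, read by MTT assay, with a stated time of 48 h (on this read-out lower numbers stand for an effect already at smaller amounts and higher numbers for an effect only at larger amounts of compound), compound 1 gives 30000 nM, the lowest of the two numbers recorded, with compound 2 as its only neighbour: a 1.1-fold higher number from compound 1 to compound 2 (0.05 log units; within the scatter). Compound 3 `CO[C@@H]1O[C@H](COc2ccc(-c3ccccc3)cc2)[C@@H](O)[C@H](O)[C@H]1Oc1cccc(C(C)C)c1` is not yet measured. It differs from compound 1 as follows: the two compounds have the same atoms and bonds and differ only in configuration as drawn: 1 of 5 stereo elements differ; a stereocentre at a saturated ring carbon is drawn S in compound 1 and R in compound 3. Among the compounds with values here, no measured step touches this stereocentre; the single step on record concerns the aryl ether and is within the scatter. Without any precedent for a change of configuration, no step beyond the scatter is expected in this assay, so compound 3 is estimated at 30000 nM (range 12000 nM to 75000 nM), meaning no change at the digits printed from compound 1 to compound 3 (within the scatter).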

Compound 3, half-maximal effective concentration: 35000 nM
Compound 3: the middle estimate sits 1.2-fold (0.07 log units) below what was measured; measured number inside the range.
By their numbers in this assay, from the lowest: compounds 1, 2 and 3 (each within the scatter of the next).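

In this assay, going by these compounds alone, the S to R switch at this saturated ring carbon gives a 1.2-fold higher number from compound 1 to compound 3 (0.07 log units; within the scatter), the first reading of a change of configuration. This stereocentre thus joins the aryl ether as a place where no step beyond the scatter has appeared. The comparison reads this stereocentre alone: the fact that compounds 1 and 3 differ only in the configuration as drawn.

The compounds shown pair both configurations only with 3-isopropylphenyl, so the stereocentre remains open with 2-isopropylphenyl. Also open, going by these compounds, is whether an amine or a carboxylic acid on the aryl ether would give a step beyond the scatter in this assay.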